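The compounds below may be only part of what the source reports. "The series", "measured", "known", "first", "only" and "open" are said of these compounds alone.

Compound 1 `Cc1cnc(Nc2ccc(C#N)cc2)nc1NC1CC1`: in an ADME assay on MT4 cells (Homo sapiens) for cytotoxicity, read by MTT assay (on this read-out higher numbers stand for lower toxicity in this test and lower numbers for higher toxicity in this test), compound 1 gives 360 nM.
Compound 2 `Cc1cnc(Nc2ccc(C#N)cc2)nc1SC1CCCCC1`: in this assay compound 2 gives 33400 nM.
Compound 3 `Cc1cnc(Nc2ccc(C#N)cc2)nc1NC1CCCC1`: in this assay compound 3 gives 170 nM.

Compound 3 holds the lowest number of the three; its nearest neighbour is compound 1, with a 2.1-fold lower number from compound 1 to compound 3 (0.33 log units; beyond the scatter) separating them, and compound 2 lies furthest away, with a 200-fold lower number from compound 2 to compound 3 (2.29 log units; beyond the scatter). Compound 4 `Cc1cnc(Nc2ccc(C#N)cc2)nc1NC1CCCCC1` differs from compound 3 by one change: cyclohexyl in place of cyclopentyl on a nitrogen on an aromatic ring. The step that bears on it is the ring growth from compound 1 to compound 3, a 2.1-fold lower number from compound 1 to compound 3 (0.33 log units; beyond the scatter), which was modest. The step from compound 2 to compound 3 also changes the sulfur-to-nitrogen link and so says less. A further modest drop, or none beyond the scatter, is expected in this assay. Compound 4 is therefore estimated at 140 nM, within 55 nM to 360 nM, a step of a 1.2-fold lower number from compound 3 to compound 4 (0.08 log units; within the scatter) that is expected.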

Compound 4, half-maximal cytotoxic concentration: 1300 nM
Beside the measured number, compound 4's estimate is 9.3-fold (0.97 log units) below it, and the stated range ends below it.
By their numbers in this assay, from the lowest: compound 3; then compound 1; then compound 4; then compound 2.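

In this assay the ring on the nitrogen does not push the number in one direction: going from cyclopentyl to cyclohexyl reverses the earlier fall (a 7.6-fold higher number from compound 3 to compound 4 (0.88 log units; beyond the scatter)), and cyclohexyl ends above cyclopropyl (a 3.6-fold higher number from compound 1 to compound 4 (0.56 log units; beyond the scatter)). With cyclohexyl now on both sides, the link can be read alone, and replacing sulfur with nitrogen still matters greatly (a 26-fold lower number from compound 2 to compound 4 (1.41 log units; beyond the scatter)). No evidence here accounts for the turn at cyclohexyl. Still open, on these data alone, are whether a cycloheptyl ring on the nitrogen would raise the number further and where a cyclohexyloxy group would fall.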